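Dropping the Acetamido Group of Compound 1

The compounds below may be only part of what the source reports. "The series", "measured", "known", "first", "only" and "open" are said of these compounds alone.

In a functional assay on NALM-6 cells (Homo sapiens); a lower number here means a stronger inhibitor, a higher number a weaker inhibitor:
compound 1 `CC(=O)N[C@@H](CSC/C=C(\C)CC/C=C(\C)CCC=C(C)C)C(=O)CCl` gives 3000 nM.
compound 2 `CC(=O)N[C@@H](CSC/C=C(\C)CCC=C(C)C)C(=O)CCl` gives only a limit, > 100000 nM.

Compound 1 holds the only number shown, while compound 2 sits at the limit of > 100000 nM in this assay, at which 1 of the 2 values shown sits. Within the data shown here, the single measured step, an at least 33-fold higher number from compound 1 to compound 2 (1.52 log units; beyond the scatter), concerns the chain alone. Among the measured compounds shown here, compound 3 `CC(C)=CCC/C(C)=C/CC/C(C)=C/CSCCC(=O)CCl` differs from compound 1 by hydrogen in place of acetamido on a saturated chain carbon bound to a carbonyl carbon and a saturated chain carbon, a change no measured step touches, so the chain step gives no guide to its size or direction. With nothing comparable to lean on, a moderate weakening is expected, a 3.3-fold higher number from compound 1 to compound 3 (0.52 log units; beyond the scatter). Compound 3 is therefore estimated at 10000 nM, with a range from 2000 nM to 100000 nM.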

Compound 3, half-maximal inhibitory concentration: 40700 nM
Beside the measured number, compound 3's estimate is 4.1-fold (0.61 log units) below it, and the stated range covers the measured number.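

In this assay, hydrogen in place of acetamido gives a 14-fold higher number from compound 1 to compound 3 (1.13 log units; beyond the scatter), so this position on the saturated chain carbon, which the earlier step left unchanged, also carries much of the activity of compound 1. The loss is large, yet compound 3 still gives a measured number rather than a limit. Nothing shown gives a cause for this step. The compounds shown leave open whether the amide as a whole is needed, since a free amine or a longer propanamido group at this place does not appear among them.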